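This account rests on a few compounds, and the source may have more. Where it says the series, first, only, none or still open, it means among the compounds named here.

Of the compounds shown here, three have been measured in a functional assay for inhibition of leukotriene B4 receptor (Homo sapiens); on this read-out higher numbers stand for weaker inhibition and lower numbers for stronger inhibition. Among the compounds with values here, compound 1 `CCc1cc(-c2ccc(F)cc2)c(O)cc1OCCCOc1cccc(CCCCC(=O)N(C)C)c1CCC(=O)O` gives 7.8 nM, and compound 2 `CCc1cc(-c2ccc(F)cc2)c(O)cc1OCCCOc1cccc(CCCCC(=O)O)c1CCC(=O)O` gives 13 nM; the one single-point step among them, a 1.7-fold higher number from compound 1 to compound 2 (0.22 log units; within the scatter), stays within the scatter, so these two values cannot be told apart. Compound 3 `CCCc1c(OCCCOc2cc(O)c(-c3ccccc3)cc2CC)ccc2c1OC(C(=O)O)CC2`, built on a different core, gives 110 nM, the highest number of the three, and its distance from both compound 2 and compound 1 is beyond the scatter.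

Compound 4 `CCCc1c(OCCCOc2cc(O)c(-c3ccc(F)cc3)cc2CC)ccc2c1OC(C(=O)O)CC2` is compound 3 with a single change: fluoro in place of hydrogen on an aromatic carbon. Within the data shown here, no measured pair shows this change by itself, so there is no step to borrow from. Compounds 1 and 2 carry the same fluorine-bearing ring, yet on another core, and their numbers are lower than that of compound 3; since the whole core differs as well, nothing in the data separates the share of the fluorine from the share of the core. What remains is a modest expectation: the step from compound 3 to compound 4 is expected to be small or not beyond the scatter, a 1.2-fold lower number from compound 3 to compound 4 (0.09 log units; within the scatter). For compound 4 the expected value in this assay is 90 nM, with a range from 40 nM to 250 nM.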

Compound 4, half-maximal inhibitory concentration: 17 nM
The estimate for compound 4 lay 5.3-fold (0.72 log units) above the measured number; the measured number lies below the stated range.
By their numbers in this assay, from the lowest: compounds 1, 2 and 4 (each within the scatter of the next, the first and the last beyond it); then compound 3.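

On the core of compound 3, replacing phenyl with 4-fluorophenyl, with the fluoro para to a large group, gives a 6.5-fold lower number from compound 3 to compound 4 (0.81 log units; beyond the scatter) in this assay. Within the data shown here, this is the first pair in which the change stands alone, so it shows that one hydrogen replaced by one fluorine at this position can shift the number beyond the scatter on this core. Compounds 1 and 2 also carry the 4-fluorophenyl group but have no partner without the fluoro, so the step can be read only on the shared core of compound 3 and compound 4, and nothing measured here explains why the change has an effect of this size.

The compounds shown leave open whether chloro, methyl or methoxy at the same place would give a step of similar size, as hydrogen and fluoro are the only two groups seen there. They also leave open whether a plain phenyl group in place of 4-fluorophenyl would move the number of compound 1 or compound 2 in the same direction and by a similar amount.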